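This account rests on a few compounds, and the source may have more. Where it says the series, first, only, none or still open, it means among the compounds named here.

Compound 3 `COc1cc2c(Oc3ccc(NC(=O)c4nnn(-c5ccc(F)c(F)c5)c4C(F)(F)F)cc3F)ccnc2cc1OCCCN1CCC(C)CC1` gives, in a functional assay on HT-29 cells (Homo sapiens) for cytotoxicity, read by MTT assay, with a stated time of 72 h (a higher number here means a weaker inhibitor, a lower number a stronger inhibitor), a value of 190 nM, the second highest of the three numbers measured. Compound 1 `COc1cc2c(Oc3ccc(NC(=O)c4nnn(-c5ccc(F)cc5)c4C(F)(F)F)cc3F)ccnc2cc1OCCCN1CCC(C)CC1` gives 160 nM in this assay, and compound 2 `COc1cc2c(Oc3ccc(NC(=O)c4nnn(-c5ccc(C)cc5)c4C(F)(F)F)cc3F)ccnc2cc1OCCCN1CCC(C)CC1` gives 1200 nM. Compound 4 `COc1cc2c(Oc3ccc(NC(=O)c4nnn(-c5cccc(Br)c5)c4C(F)(F)F)cc3F)ccnc2cc1OCCCN1CCC(C)CC1` carries 3-bromophenyl in place of 3,4-difluorophenyl on an aromatic nitrogen. Within the data shown here, two measured steps bear on this change: a 1.2-fold higher number from compound 1 to compound 3 (0.07 log units; within the scatter), and a 6.3-fold lower number from compound 2 to compound 3 (0.80 log units; beyond the scatter). Adding one fluoro to the phenyl ring thus changed little, while exchanging the whole ring for one bearing a methyl moved the number by a modest amount. No 3-bromophenyl has been measured here, so a modest step is expected, most likely towards a higher number, a 1.7-fold higher number from compound 3 to compound 4 (0.23 log units; within the scatter). Compound 4 is therefore expected to give about 320 nM in this assay, within a range from 110 nM to 1000 nM.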

Compound 4, half-maximal inhibitory concentration: 380 nM
Compound 4: middle estimate off by 1.2-fold (0.07 log units), on the low side; the range from low to high includes it.
By their numbers in this assay, from the lowest: compounds 1, 3 and 4 (each within the scatter of the next, the first and the last beyond it); then compound 2.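

In this assay, 3-bromophenyl on this aromatic nitrogen shows that a ring bearing bromine can stay well clear of the 4-methylphenyl result, with a 3.2-fold lower number from compound 2 to compound 4 (0.50 log units; beyond the scatter). Its gap to the 3,4-difluorophenyl ring is small, at a 2.0-fold higher number from compound 3 to compound 4 (0.30 log units; within the scatter), but the gap to the 4-fluorophenyl ring is larger, at a 2.4-fold higher number from compound 1 to compound 4 (0.38 log units; beyond the scatter). The position therefore accepts a bromine-bearing ring, though 4-fluorophenyl remains ahead of it.

Nothing available explains why these groups differ. On these data alone, how an aminophenyl or a carboxylic acid on this ring would behave remains open.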